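From a propanoyl group to 2-(dimethylamino)ethyl

The compounds below may be only part of what the source reports. "The series", "measured", "known", "first", "only" and "open" are said of these compounds alone.

Values in an ADME assay on BaF3 cells (Mus musculus) for cytotoxicity, read by CellTiter-Glo and CCK-8 assay, with a stated time of 72 h (a lower number here means a stronger inhibitor of growth, a higher number a weaker inhibitor of growth), are:
- compound 1 (`CCC(=O)NCc1ccc(C(=O)Nc2ccc(C)c(Nc3nccc(-c4cccnc4)n3)c2)cc1`) gives > 10000 nM as a limit
- compound 2 (`CCC(=O)Nc1ccc(C(=O)Nc2ccc(C)c(Nc3nccc(-c4cccnc4)n3)c2)cc1`) gives > 10000 nM as a limit
- compound 3 (`C=CC(=O)Nc1cc(C(=O)Nc2ccc(C)c(Nc3nccc(-c4cccnc4)n3)c2)cc(C(F)(F)F)c1`) gives 5460 nM as a number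

Compound 1 has no number in this assay, only a limit (> 10000 nM). Across the series, the picture is the limit of > 10000 nM in this assay, at which 2 of the 3 values shown sit, and compound 1 is one of those two.

Compound 4 (`Cc1ccc(NC(=O)c2ccc(CNCCN(C)C)cc2)cc1Nc1nccc(-c2cccnc2)n1`) changes compound 1 in a single place, with 2-(dimethylamino)ethyl in place of propanoyl on an amine nitrogen. Going by the values given here, only one measured step touches this part of the molecule. It is a step that the two limits leave unreadable from compound 1 to compound 2 and gives no size to carry over. Among the compounds with values here, compound 3 supplies the only number (5460 nM), but no measured step links it to compound 1, so it serves only as a rough guide to the range in which a number might fall.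

With no readable step to draw on, only a small move toward stronger growth inhibition is expected, and its size is poorly defined. The expected change is an at least 1.1-fold lower number from compound 1 to compound 4 (0.04 log units; that floor lies within the scatter) and this remains a loose estimate. For compound 4 the estimated value is 9000 nM, with an expected range from 3000 nM to 20000 nM and a real chance that only a limit is reported.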

Compound 4, concentration for 50% growth inhibition: > 10000 nM
Compound 4 was reported as a limit (the forecaster's own chance of this, stated with the estimate: 55%); middle value at least 1.1-fold (0.04 log units) away from the limit.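

In this assay compound 4 gives > 10000 nM, which is a limit and not a number. Compound 1 and compound 2 also stand only at limits, so no step among these three compounds can be read. The compounds shown leave open whether 2-(dimethylamino)ethyl in place of propanoyl changes growth inhibition at all, and by how much: the limit of > 10000 nM in this assay, at which 3 of the 4 values shown sit.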